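The compounds below may be only part of what the source reports. "The series", "measured", "known", "first", "only" and "open" are said of these compounds alone.

Compound 1 `CC#C[C@@H](Cc1nnn[nH]1)c1ccc(OCc2ccc3sc(F)c(-c4ccccc4C)c3c2)cc1` gives 2.7 h
Compound 2 `CC#C[C@@H](Cc1nnn[nH]1)c1ccc(OCc2ccc3scc(-c4ccc(OCCCS(C)(=O)=O)cc4C)c3c2)cc1` gives 2.8 h

Among the compounds with values here, these are the only two compounds measured so far in an ADME assay on the whole organism for metabolic stability, with Rattus norvegicus as the target, at a dose of 10 mg/kg by the oral route (a higher number here means that the compound lasts longer, a lower number that the compound disappears faster), and their numbers lie within the usual scatter of each other. Compound 1 therefore cannot be told apart from compound 2 on this read-out, and neither can be called the longer lasting.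

Compound 3 `CC#C[C@@H](Cc1nnn[nH]1)c1ccc(OCc2ccc3sc(Cl)c(-c4ccccc4C)c3c2)cc1` has not yet been measured. It departs from compound 1 in one place, with chloro in place of fluoro on an aromatic carbon of a five-membered aromatic ring with 1 sulfur, next to the ring sulfur.

Within the data shown here, no pair of measured compounds shows this swap or any other single change, so the data give no direct guide to its size or direction. The best starting point is compound 1 itself, at 2.7 h in this assay and no shift beyond the scatter is expected. The estimated change, a 1.1-fold higher number from compound 1 to compound 3 (0.05 log units; within the scatter), is expected to stay within that scatter. For compound 3 the estimated half-life is 3 h, with an expected range from 1.6 h to 5 h.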

Compound 3, half-life: 2.2 h
The estimate for compound 3 lay 1.4-fold (0.13 log units) above the measured number; low and high end bracket the measured number.
By their numbers in this assay, from the lowest: compounds 3, 1 and 2 (each within the scatter of the next).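

Within the data shown here, the step from fluoro to chloro, on an aromatic carbon next to the ring sulfur, is the first single change that can be read in this assay, and it comes to a 1.2-fold lower number from compound 1 to compound 3 (0.09 log units; within the scatter). In this one pair, the two halogens cannot be told apart on half-life, so the position accepts either of them without a shift that stands out from the normal variation between repeated measurements. Nothing measured here bears on why the swap has so little effect.

The compounds shown carry only fluoro or chloro at this carbon in a comparable setting: compound 2 has a hydrogen there but also differs in the group on the neighbouring ring atom, so it cannot serve as a clean comparison. Going by these compounds, it remains open whether a different group at this position, such as a methyl, a nitrile, an amine or a carboxylic acid, would move the half-life beyond the scatter, and whether the fluoro to chloro swap would behave the same way with another group in place of the 2-methylphenyl group.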